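A few compounds are considered here, and "the series" means these few. Any claim that something is new, unique, unknown or untested is made for them only; others in the source may bear on it.

Compound 1, `COc1ccc(C(=O)/C=C/c2cc(-c3cc(OC)c(OC)c(OC)c3)n[nH]2)cc1OC`, is the starting point. For the measured compounds named here, in a functional assay on U-251 cells (Homo sapiens) for cytotoxicity, read by sulforhodamine B assay, with a stated time of 48 h, tested at 0.1 uM (a lower number here means a stronger effect, a higher number a weaker effect of the compound at the concentration tested), compound 1 gives 95%, which is the lowest of the two numbers measured so far. Its nearest neighbour is compound 2, `COc1ccc(C(=O)/C=C/c2cc(-c3cc(OC)c(OC)c(OC)c3)n[nH]2)cc1`, which in this assay gives 97%; the step of a number 2 percentage points higher from compound 1 to compound 2 (within the scatter), hydrogen in place of methoxy on an aromatic carbon, stays within the scatter, so the two values cannot be told apart.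

Compound 3, `COc1cc(C(=O)/C=C/c2cc(-c3cc(OC)c(OC)c(OC)c3)n[nH]2)cc(OC)c1OC`, has not yet been measured. It differs from compound 1 as follows: methoxy in place of hydrogen on an aromatic carbon. Going by the values given here, the only measured step that bears on this change is the one from compound 1 to compound 2, and it was too small to rise above the scatter. A methoxy entering rather than leaving is therefore expected to move the number little as well, with no direction beyond the scatter. The expected step is a number 2 percentage points lower from compound 1 to compound 3 (within the scatter). For compound 3 the estimate is 93%, with a range from 80% to 102%.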

Compound 3, a percentage reported as activity, at one concentration (the size of the read-out at that concentration, not a potency): 94%
Compound 3: middle estimate off by 1 percentage points, on the low side; the range from low to high includes it.
By their numbers in this assay, from the lowest: compounds 3, 1 and 2 (each within the scatter of the next).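

In this assay, methoxy in place of hydrogen, on the aromatic carbon ortho to a methoxy group, gives a number 1 percentage points lower from compound 1 to compound 3 (within the scatter). The earlier step, a number 2 percentage points higher from compound 1 to compound 2 (within the scatter), showed only the loss of a methoxy from this ring; the new one shows that adding a methoxy also leaves the number within the scatter, so on this ring neither change from compound 1 can be told apart from it. Nothing measured here offers an explanation for this result.

The compounds shown carry only hydrogen or methoxy on this ring, so it remains open whether an amine, a carboxylic acid or a longer chain such as butoxy at this place would shift the number beyond the scatter. As far as these compounds go, whether changes elsewhere on the core of compound 1 would do so also remains open.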